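Swapping an aryl group for hexyl on the triazole

This account rests on a few compounds, and the source may have more. Where it says the series, first, only, none or still open, it means among the compounds named here.

Measured in a functional assay on HeLa cells (Homo sapiens) for antiproliferative activity, read by sulforhodamine B assay, with a stated time of 48 h; a lower number here means a stronger inhibitor of growth, a higher number a weaker inhibitor of growth:
compound 1 `O=C1COc2ccccc2N1CCCn1cc(-c2ccccc2)nn1`: 9000 nM
compound 2 `Cc1ccc(-c2cn(CCCN3C(=O)COc4ccccc43)nn2)cc1`: 14300 nM
compound 3 `COc1ccc(-c2cn(CCCN3C(=O)COc4ccccc43)nn2)cc1`: 4900 nM

On these numbers, compound 3 is only partly separated from the other two. Its gap to the unsubstituted phenyl compound, a 1.8-fold lower number from compound 1 to compound 3 (0.26 log units; within the scatter), stays within the scatter, and the same holds for a 1.6-fold higher number from compound 1 to compound 2 (0.20 log units; within the scatter). Only a 2.9-fold lower number from compound 2 to compound 3 (0.47 log units; beyond the scatter) goes beyond the scatter, and then modestly.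

The next compound is compound 4 `CCCCCCc1cn(CCCN2C(=O)COc3ccccc32)nn1`, with hexyl in place of 4-methoxyphenyl on an aromatic carbon. Among the compounds with values here, none of the measured steps removes the aromatic ring, so the series offers no direct precedent for this change. The three steps bear on it only indirectly, as they show how far this assay has moved with small changes on that ring. The largest of them, a 2.9-fold lower number from compound 2 to compound 3 (0.47 log units; beyond the scatter), is modest, and this sets a loose scale rather than a prediction. Within the data shown here, no step clearly beyond the scatter is therefore expected, although a replacement this large leaves the direction uncertain. The estimated change is a 1.4-fold higher number from compound 3 to compound 4 (0.15 log units; within the scatter), a slight move towards the values of the other two compounds. For compound 4 the expected value is 7000 nM, with an estimated range from 2000 nM to 25000 nM.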

Compound 4, concentration for 50% growth inhibition: 100 nM
Beside the measured number, compound 4's estimate is 70-fold (1.85 log units) above it; the measured number lies below the stated range.
By their numbers in this assay, from the lowest: compound 4; then compounds 3, 1 and 2 (each within the scatter of the next, the first and the last beyond it).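

In this assay, this carbon of the five-membered aromatic ring with 3 nitrogen proves far more responsive than the small changes on the aromatic ring had suggested: replacing 4-methoxyphenyl with hexyl gives a 49-fold lower number from compound 3 to compound 4 (1.69 log units; beyond the scatter), well beyond the largest earlier step, a 2.9-fold lower number from compound 2 to compound 3 (0.47 log units; beyond the scatter). The result does not depend on which aromatic group leaves, as hexyl also gives a 140-fold lower number from compound 2 to compound 4 (2.16 log units; beyond the scatter) in place of 4-methylphenyl and a 90-fold lower number from compound 1 to compound 4 (1.95 log units; beyond the scatter) in place of phenyl, making compound 4 the strongest inhibitor of growth among the four compounds. No measurement at hand accounts for the size of these steps.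

With hexyl as the only open chain here, the compounds leave open whether the gain follows from the chain itself or simply from losing the aromatic ring, a question that a butyl chain, a longer octyl chain or a cyclohexyl ring at this carbon would address. They also leave open whether the chain tolerates a hydroxyl group or an amine at its far end, and whether the steep change seen with hexyl persists in other cell lines.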